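Ring-for-chain swap on the sulfur substituent

The source may report more compounds than this note shows. Statements on the series, on what has been measured and on what is new or still open speak of the compounds shown alone.

Measured in an assay on cells for antagonist activity at transient receptor potential cation channel subfamily V member 1 (Homo sapiens), read by FLIPR and calcium flux, with a stated time of 6 min; a lower number here means a stronger inhibitor, a higher number a weaker inhibitor:
compound 1, `CCOc1nc(C(C)(C)C)ccc1CNC(=O)C(C)c1ccc(NS(C)(=O)=O)c(F)c1`: 14.8 nM
compound 2, `CC(C(=O)NCc1ccc(C(C)(C)C)nc1OC1CCCCC1)c1ccc(NS(C)(=O)=O)c(F)c1`: 2.5 nM
compound 3, `CCCCCCSc1nc(C(C)(C)C)ccc1CNC(=O)C(C)c1ccc(NS(C)(=O)=O)c(F)c1`: 1.5 nM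

Compound 3 holds the lowest number of the three. Its distance from compound 1 is clear, a 9.9-fold lower number from compound 1 to compound 3 (0.99 log units; beyond the scatter), whereas its distance from compound 2 is not, a 1.7-fold lower number from compound 2 to compound 3 (0.22 log units; within the scatter), so compound 3 and compound 2 cannot be ordered on these data.

The next compound, compound 4, `CC(C(=O)NCc1ccc(C(C)(C)C)nc1SC1CCCC1)c1ccc(NS(C)(=O)=O)c(F)c1`, differs from compound 3 in one place: cyclopentyl in place of hexyl on a sulfur. Among the compounds with values here, two measured steps bear on it. The step of a 5.9-fold lower number from compound 1 to compound 2 (0.77 log units; beyond the scatter) shows that a ring in place of a short chain on the oxygen lowered the number; the step of a 1.7-fold lower number from compound 2 to compound 3 (0.22 log units; within the scatter) shows that a six-membered ring on oxygen and a hexyl chain on sulfur sit within the scatter of each other. Compound 4 keeps the sulfur of compound 3 and carries a five-membered ring, a motif lying between those two cases. Compound 4 is therefore expected to stay close to compound 3, the expected step being a 1.7-fold higher number from compound 3 to compound 4 (0.22 log units; within the scatter), not beyond the scatter in either direction. The estimate for compound 4 in this assay is 2.5 nM, with a range from 1 nM to 6.5 nM.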

Compound 4, inhibition constant: 2.5 nM
Compound 4: the middle estimate sits on the measured number at the digits printed; measured number inside the range.
By their numbers in this assay, from the lowest: compounds 3, 2 and 4 (each within the scatter of the next); then compound 1.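

In this assay, cyclopentyl on the sulfur does about as well as hexyl (a 1.7-fold higher number from compound 3 to compound 4 (0.22 log units; within the scatter)), so on these two compounds an open chain is not required at this place, and a five-membered non-aromatic ring of carbon only is accepted there. The cyclopentylsulfanyl and cyclohexyloxy groups cannot be told apart (no change at the digits printed from compound 2 to compound 4 (within the scatter)), whereas replacing ethoxy with cyclopentylsulfanyl gives a step beyond the scatter (a 5.9-fold lower number from compound 1 to compound 4 (0.77 log units; beyond the scatter)), the same size as the step from ethoxy to cyclohexyloxy (a 5.9-fold lower number from compound 1 to compound 2 (0.77 log units; beyond the scatter)). No measurement on hand bears on the reason for any of these steps.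

The sulfur and oxygen linkers never carry the same substituent in the compounds shown, so their separate contributions stay unresolved; ethyl on sulfur, cyclopentyl on oxygen or cyclohexyl on sulfur would each isolate one change at this place. Also open, on these data alone, is whether this place accepts anything other than carbon-only substituents, such as a morpholine or piperidine ring, an amine or a carboxylic acid at the end of a chain.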